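From 2,3-Dichlorophenyl to 3-Chloro-4-hydroxyphenyl

The compounds below may be only part of what the source reports. "The series", "measured", "known", "first", "only" and "open" are said of these compounds alone.

In a functional assay on SW-620 cells (Homo sapiens) for cytotoxicity, read by MTT assay, with a stated time of 72 h (on this read-out lower numbers stand for stronger inhibition and higher numbers for weaker inhibition), compound 1 `COc1ccc(/C=C2\CCC/C(=C\c3cccc(O)c3)C2=O)cc1OC` gives 1900 nM, while compound 2 `COc1ccc(/C=C2\CCC/C(=C\c3cccc(Cl)c3Cl)C2=O)cc1OC` gives 10800 nM, the higher of the two numbers. Compound 3 `COc1ccc(/C=C2\CCC/C(=C\c3ccc(O)c(Cl)c3)C2=O)cc1OC` remains unmeasured and differs from compound 2 at one place: 3-chloro-4-hydroxyphenyl in place of 2,3-dichlorophenyl on a double-bonded chain carbon bound to a double-bonded ring carbon. Among the compounds with values here, the only measured step bearing on this change is a 5.7-fold higher number from compound 1 to compound 2 (0.75 log units; beyond the scatter), where 2,3-dichlorophenyl took the place of 3-hydroxyphenyl. Compound 3 regains a hydroxy group but keeps a chlorine, so only a partial return toward lower numbers is expected, estimated as a 3.1-fold lower number from compound 2 to compound 3 (0.49 log units; beyond the scatter). For compound 3 the expected value is 3500 nM, with an estimated range from 1200 nM to 9000 nM.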

Compound 3, half-maximal inhibitory concentration: 7100 nM
Compound 3: middle estimate off by 2.0-fold (0.31 log units), on the low side, within the range that was stated.
By their numbers in this assay, from the lowest: compound 1; then compounds 3 and 2 (each within the scatter of the next).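

In this assay, 3-chloro-4-hydroxyphenyl in place of 2,3-dichlorophenyl gives a 1.5-fold lower number from compound 2 to compound 3 (0.18 log units; within the scatter) and so does not separate the two compounds at this position. In place of 3-hydroxyphenyl, the same group gives a 3.7-fold higher number from compound 1 to compound 3 (0.57 log units; beyond the scatter) and shows that a hydroxy group on this ring does not alone preserve the number of compound 1. Nothing available explains either step. From the compounds shown here alone, it remains open whether the chlorine or the placement of the hydroxy group accounts for the second step. Going by these compounds, how an amine or a carboxylic acid on this ring would read out also remains open.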